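From isopropyl to chloromethyl on a shared core

This account rests on a few compounds, and the source may have more. Where it says the series, first, only, none or still open, it means among the compounds named here.

Values in an ADME assay on CEMx174 cells (Homo sapiens) for cytotoxicity; on this read-out lower numbers stand for higher toxicity in this test and higher numbers for lower toxicity in this test:
- compound 1 `CC1=C(C(=O)OCc2ccccc2)C(c2cccc(O)c2)NC(=O)N1`: > 10000 nM (a limit of the assay)
- compound 2 `CCCC1=C(C(=O)OCC2CCCCC2)C(c2cccc(O)c2)NC(=O)N1`: > 10000 nM (a limit of the assay)
- compound 3 `CC(C)C1=C(C(=O)OCC2CCCCC2)C(c2cccc(O)c2)NC(=O)N1`: "not determined" (no result reported)

Compound 3 has no number to start from, its entry in this assay reading "not determined" (no result reported). The only anchor nearby is the limit of > 10000 nM in this assay, at which 2 of the 3 values shown sit. Compound 4 `O=C1NC(CCl)=C(C(=O)OCC2CCCCC2)C(c2cccc(O)c2)N1` has yet to be measured. The change is chloromethyl in place of isopropyl on a double-bonded ring carbon, with chloromethyl in place of isopropyl on a double-bonded ring carbon. Among the measured compounds shown here, no measured step gives a size for this change. A modest move toward lower numbers in this assay is expected, and a result at the limit would be no surprise. For compound 4 the estimated value is 7000 nM, with an expected range of 1500 nM to 20000 nM.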

Compound 4, half-maximal cytotoxic concentration: > 3000 nM
Compound 4 was reported as a limit; the forecaster's own chance of this, stated with the estimate: 55%; the middle value lies beyond the limit too.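

No new step can be read: compound 2 and compound 4 both stand only as limits, and compound 3 has no result. The compounds shown leave open whether chloromethyl in place of isopropyl changes the read-out at all.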